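Swapping a hydroxyalkyl amide for a dicarboxyethyl amide

This account rests on a few compounds, and the source may have more. Where it says the series, first, only, none or still open, it means among the compounds named here.

Compound 1 `CCn1c(C(=O)NC(C)(C)CO)ccc1C(CC)(CC)c1ccc(OCS(=O)(=O)c2ccccc2)c(C)c1` is tested in a functional assay on PC-3 cells (Homo sapiens) for antiproliferative activity, read by MTT assay, with a stated time of 24 h (on this read-out higher numbers stand for weaker inhibition and lower numbers for stronger inhibition), where compound 1 gives 9850 nM. Among the three measured compounds it carries the highest number, but its neighbours sit close: compound 2 `CCn1c(C(=O)N[C@H](CO)C(C)C)ccc1C(CC)(CC)c1ccc(OCS(=O)(=O)c2ccccc2)c(C)c1` gives 7300 nM and compound 3 `CCn1c(C(=O)N[C@H](CO)CCCO)ccc1C(CC)(CC)c1ccc(OCS(=O)(=O)c2ccccc2)c(C)c1` gives 6810 nM. The steps from compound 1 are a 1.3-fold lower number from compound 1 to compound 2 (0.13 log units; within the scatter) and a 1.4-fold lower number from compound 1 to compound 3 (0.16 log units; within the scatter), and between the other two the step is a 1.1-fold lower number from compound 2 to compound 3 (0.03 log units; within the scatter); all three changes on the amide-type nitrogen leave the read-out essentially unmoved.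

Compound 4 `CCn1c(C(=O)N[C@H](CC(=O)O)C(=O)O)ccc1C(CC)(CC)c1ccc(OCS(=O)(=O)c2ccccc2)c(C)c1` differs from compound 1 by 1,2-dicarboxyethyl in place of 1-(hydroxymethyl)-1-methylethyl on an amide-type nitrogen. For the measured compounds named here, none of the measured steps involves a carboxylic acid, so they bear on this change only in showing that the three hydroxyalkyl groups tried so far give numbers within the scatter of one another. Compound 4 is therefore expected to land near compound 1, with a step of a 1.2-fold higher number from compound 1 to compound 4 (0.09 log units; within the scatter), and the estimate is 12000 nM, ranging from 4000 nM to 40000 nM.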

Compound 4, half-maximal inhibitory concentration: > 50000 nM
Compound 4 was reported as a limit (the forecaster's own chance of this, stated with the estimate: 20%); middle value at least 4.1-fold (0.61 log units) from the limit.
By their numbers in this assay, from the lowest: compounds 3, 2 and 1 (each within the scatter of the next). At a limit, above all of these: compound 4.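

In this assay compound 4 is reported only as a limit of the assay, not as a number: the limit of > 50000 nM in this assay, at which 1 of the 4 values shown sits. For the compounds shown here, the 1,2-dicarboxyethyl group brings the first steps beyond the scatter at this position on the amide-type nitrogen: an at least 5.0-fold higher number from compound 1 to compound 4 (0.70 log units; beyond the scatter), an at least 6.8-fold higher number from compound 2 to compound 4 (0.83 log units; beyond the scatter) and an at least 7.3-fold higher number from compound 3 to compound 4 (0.86 log units; beyond the scatter). The position therefore does respond to what is placed there, which the three hydroxyalkyl groups, all within the scatter of one another, did not reveal.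

On these data alone, how far compound 4 lies past its limit remains open. The change replaces the whole group at once, and the data do not show which part of the group the step goes with. A group with a single carboxylic acid, or a methyl ester of either carboxylic acid, would show whether one acid is enough for the step or whether both are needed.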